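Swapping a benzyl group at the cytotoxicity limit

The source may report more compounds than this note shows. Statements on the series, on what has been measured and on what is new or still open speak of the compounds shown alone.

In an ADME assay on cells (Peritoneal macrophage, Mus musculus, strain Balb/c) for cytotoxicity, read by resazurin assay, with a stated time of 72 h (on this read-out lower numbers stand for higher toxicity in this test and higher numbers for lower toxicity in this test), compound 2 `CC1(Cc2cccc(CO)c2)CC(S(=O)(=O)c2ccc(F)cc2)=C(c2ccc(/C(N)=N/O)cc2)O1` gives > 100000 nM and that is a limit of the assay, not a number. Compound 1 `COc1cc(CC2(C)CC(S(=O)(=O)c3ccc(F)cc3)=C(c3ccc(/C(N)=N/O)cc3)O2)cc(OC)c1OC` gives 92300 nM in this assay and so has a true number. Compound 2 carries 3-(hydroxymethyl)phenyl where compound 1 carries 3,4,5-trimethoxyphenyl, and the measured step is an at least 1.0-fold higher number from compound 1 to compound 2 (0.03 log units; that floor lies within the scatter) for that exchange. On these data alone, its size is only a floor, set by the limit of > 100000 nM in this assay, at which 1 of the 2 values shown sits, and so the real gap stays unknown.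

Compound 3 `CC1(Cc2ccccc2Br)CC(S(=O)(=O)c2ccc(F)cc2)=C(c2ccc(/C(N)=N/O)cc2)O1` brings the next change to the same place, with 2-bromophenyl in place of 3-(hydroxymethyl)phenyl on a saturated chain carbon bound to a saturated ring carbon. Among the compounds with values here, the single step from compound 1 to compound 2 is the only guide here, and it did not go beyond the scatter. No step beyond the scatter is therefore expected for this new exchange in this assay either. The estimated change is an at least 1.1-fold lower number from compound 2 to compound 3 (0.04 log units; that floor lies within the scatter) in this reading. For compound 3 the expected value is estimated at 90000 nM (35000 nM to 200000 nM).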

Compound 3, half-maximal cytotoxic concentration: 109000 nM
Beside the measured number, compound 3's estimate is 1.2-fold (0.08 log units) below it; the measured number falls inside the stated range.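

In this assay, within the data shown here, the exchange of 3,4,5-trimethoxyphenyl for 2-bromophenyl on a saturated chain carbon bound to a saturated ring carbon gives the first comparison at this place between two true numbers (a 1.2-fold higher number from compound 1 to compound 3 (0.07 log units; within the scatter)). Two quite different substituted phenyl groups can therefore stand at this place without a step beyond the scatter, and the earlier pair could offer only a floor for its step, not a real size. Compound 2 remains a limit of the assay and not a number, and its step to compound 3 cannot be read because of that limit: the limit of > 100000 nM in this assay, at which 1 of the 3 values shown sits.

All three compounds shown carry a substituted phenyl group at this place, so it stays open whether an amine or a carboxylic acid on that ring, or a longer chain in place of the benzyl link, would move the number beyond the scatter. On these data alone, whether the shared core rather than this group sets the level of these values also stays open.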